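A Fluorine Removed from a Weakly Active Compound

The compounds below may be only part of what the source reports. "The series", "measured", "known", "first", "only" and "open" are said of these compounds alone.

In a functional assay on HT-29 cells (Homo sapiens) for inhibition, read by MTT assay, with a stated time of 48 h (on this read-out higher numbers stand for weaker inhibition and lower numbers for stronger inhibition), three compounds sharing one core were examined. Compound 1 `CC(C)n1c(S)nnc1Sc1nnc(-c2ccccc2)n1-c1ccccc1` has "not determined" (no result reported) in this assay, and compound 2 `CCOc1ccc(-n2c(S)nnc2CSc2nnc(-c3ccccc3)n2-c2ccccc2)cc1` likewise has "not determined" (no result reported). Going by the values given here, compound 3 `Fc1ccc(-n2c(S)nnc2Sc2nnc(-c3ccccc3)n2-c2ccccc2)cc1` is the only one with a number: in this assay compound 3 gives 32800 nM, which marks it as weakly active, with no other value to set beside it.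

Compound 4 `Sc1nnc(Sc2nnc(-c3ccccc3)n2-c2ccccc2)n1-c1ccccc1` differs from compound 3 in a single place: hydrogen in place of fluoro on an aromatic carbon. One fluorine leaves and a hydrogen enters, with no change in hydrogen-bond donors or acceptors and no change in charge, at an aromatic carbon of a six-membered aromatic ring of carbon only, para to a large group.

Among the compounds with values here, no pair of measured compounds shows what such a change does, so the expectation rests on the small size of the change and on the one number available. The step is expected to be a 1.1-fold higher number from compound 3 to compound 4 (0.03 log units; within the scatter), which is not expected to reach beyond the usual scatter of this assay. Compound 4 is therefore expected to give 35000 nM in this assay, with a range from 12000 nM to 100000 nM.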

Compound 4, half-maximal inhibitory concentration: 28300 nM
Compound 4: middle estimate off by 1.2-fold (0.09 log units), on the high side; the range from low to high includes it.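

In this assay, hydrogen in place of fluoro on an aromatic carbon gives a 1.2-fold lower number from compound 3 to compound 4 (0.06 log units; within the scatter). Going by these compounds alone, this is the first step that can be read, and it shows that the change from 4-fluorophenyl to phenyl leaves the number within the scatter, so that compound 3 and compound 4 cannot be told apart in this assay and the fluorine is not required for the weak activity seen in this pair. The compounds shown offer no information that could explain this result.

What this single step leaves open is whether this aromatic carbon tolerates any group, since fluoro and hydrogen are the only two substituents compared there with numbers on both sides. An amine or a carboxylic acid at the same place, para to a large group, might move the number beyond the scatter or might leave it where it is, and the present pair cannot tell which of these would happen, nor whether changes elsewhere on the shared core would matter more.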